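A Chloro-to-Fluoro Exchange on an Aromatic Carbon

The source may hold more compounds than are shown below. What is called first, only, known or untested is meant among the compounds shown, and "the series" means these compounds.

In a functional assay on HepG2 cells (Mus musculus) for antiproliferative activity against HepG2 (Homo sapiens), read by MTT assay, with a stated time of 48 h (a higher number here means a weaker inhibitor, a lower number a stronger inhibitor), compound 1 (`COc1ccc(C(=O)Nc2nnc(/C=C/c3cc(OC)c(OC)c(OC)c3Br)s2)cc1`) gives 220 nM and compound 2 (`COc1cc(/C=C/c2nnc(NC(=O)c3ccccc3Br)s2)c(Br)c(OC)c1OC`) gives 250 nM on the same scale. Compound 3 (`COc1cc(/C=C/c2nnc(NC(=O)c3cccc(Cl)c3)s2)c(Br)c(OC)c1OC`) gives 150 nM there, a value within the scatter of both others, so the three cannot be ranked.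

Compound 4 (`COc1cc(/C=C/c2nnc(NC(=O)c3cccc(F)c3)s2)c(Br)c(OC)c1OC`) has fluoro in place of chloro on an aromatic carbon, meta to a large group (fluoro in place of chloro on an aromatic carbon). For the measured compounds named here, no measured step makes this exchange itself. The closest evidence comes from exchanges of the whole group on the carbonyl carbon: a 1.5-fold lower number from compound 1 to compound 3 (0.17 log units; within the scatter) when 3-chlorophenyl replaces 4-methoxyphenyl, a 1.7-fold lower number from compound 2 to compound 3 (0.22 log units; within the scatter) when 3-chlorophenyl replaces 2-bromophenyl, and a 1.1-fold higher number from compound 1 to compound 2 (0.06 log units; within the scatter) when 2-bromophenyl replaces 4-methoxyphenyl. All three stay within the scatter, and the exchange in compound 4 touches a single atom of that group. With compound 3 at 150 nM as the starting point, no step beyond the scatter is expected in this assay, and the data name no direction. The estimated step is small (a 1.1-fold higher number from compound 3 to compound 4 (0.05 log units; within the scatter)). For compound 4 the expected value is 170 nM, with an estimated range from 85 nM to 340 nM for repeated measurements.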

Compound 4, half-maximal inhibitory concentration: 170 nM
Compound 4: middle estimate and measured number agree at the digits printed; measured number inside the range.
By their numbers in this assay, from the lowest: compounds 3, 4, 1 and 2 (each within the scatter of the next).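

The measured step for this exchange in this assay is a 1.1-fold higher number from compound 3 to compound 4 (0.05 log units; within the scatter) and this places fluoro and chloro within the scatter of each other on this aromatic carbon, meta to a large group. The 3-fluorophenyl group on the carbonyl carbon also cannot be told apart from the two other groups, with a 1.5-fold lower number from compound 2 to compound 4 (0.17 log units; within the scatter) and a 1.3-fold lower number from compound 1 to compound 4 (0.11 log units; within the scatter) as its steps, so every exchange on this carbonyl carbon among the four compounds now stays within the scatter. No measurement that could bear on the reason for these small steps accompanies the values.

Whether an amine or a carboxylic acid on this same aromatic carbon would give a step beyond the scatter remains open, since chloro and fluoro are the only groups shown there. For the compounds shown here, also open is whether fluoro in place of chloro would give so small a step on a core other than the one shared by compound 3 and compound 4, or in any other assay.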